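The source may report more compounds than this note shows. Statements on the series, on what has been measured and on what is new or still open speak of the compounds shown alone.

Three compounds with a shared carboxylic acid on a ring attached to an aromatic ring have been measured in an assay on cells for inhibition of Palmitoleoyl-protein carboxylesterase NOTUM variant C330S (Homo sapiens), read by fluorescence, with a stated time of 40 min; on this read-out lower numbers stand for stronger inhibition and higher numbers for weaker inhibition. Compound 1, `O=C(O)C1CCN(c2ccccc2)C1`, gives 48000 nM. Compound 2, `COc1cccc(-n2c(C)cc(C(=O)O)c2C)c1`, gives 1500 nM. Compound 3, `O=C(O)C1CCN(c2ccc(C(F)(F)F)cc2)C1`, gives 50000 nM, the highest number of the three; its nearest neighbour is compound 1, which sits within the usual scatter of it, while compound 2 lies far below it, beyond the scatter.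

The next compound, compound 4, is `O=C(O)C1CCN(c2ccc(F)cc2)C1`. It differs from compound 3 in one place: fluoro in place of trifluoromethyl on an aromatic carbon.

Going by the values given here, only one measured step bears on this change, the one in which a hydrogen at the same position of the aromatic ring is exchanged for the trifluoromethyl group: a 1.0-fold higher number from compound 1 to compound 3 (0.02 log units; within the scatter). Since adding the whole trifluoromethyl group to that position left the number unchanged within the scatter, replacing it by the smaller fluoro is not expected to move the number beyond the scatter either, in this assay.

The expectation for compound 4 is therefore a number close to that of compound 3, that is a 1.0-fold lower number from compound 3 to compound 4 (0.02 log units; within the scatter), giving an estimate of 48000 nM with a range from 24000 nM to 96000 nM.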

Compound 4, half-maximal inhibitory concentration: 15000 nM
Compound 4: middle estimate off by 3.2-fold (0.51 log units), on the high side; the measured number lies below the stated range.
By their numbers in this assay, from the lowest: compound 2; then compound 4; then compounds 1 and 3 (each within the scatter of the next).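

In this assay, the earlier step between hydrogen and trifluoromethyl, a 1.0-fold higher number from compound 1 to compound 3 (0.02 log units; within the scatter), made this position on the aromatic ring look indifferent to what it carries, but fluoro shows otherwise, with a 3.3-fold lower number from compound 3 to compound 4 (0.52 log units; beyond the scatter) and a 3.2-fold lower number from compound 1 to compound 4 (0.51 log units; beyond the scatter). Both steps are modest, yet they show that a change at this carbon can move the number, and that the outcome does not track the count of heavy atoms: fluoro, with 1 heavy atom, stands apart both from hydrogen and from trifluoromethyl, with 4 heavy atoms, although those two lie within the scatter of each other. No supporting measurement is available to explain why fluoro alone separates from the other two groups.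

The compounds shown leave open whether other single atoms or small groups at this carbon, such as chloro, methyl or methoxy, would match fluoro or fall back to the level of hydrogen. They also leave open whether fluoro would give a similar step on another carbon of the aromatic ring, or on the core of compound 2.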